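Amide substituent variation on a dilauroyl cysteine thioglycerol series

The source may report more compounds than this note shows. Statements on the series, on what has been measured and on what is new or still open speak of the compounds shown alone.

Measured so far:
compound 1 `CCCCCCCCCCCC(=O)OC[C@H](CSC[C@@H](N)C(=O)NC(C)(C)CO)OC(=O)CCCCCCCCCCC`, 15500 nM
compound 2 `CCCCCCCCCCCC(=O)OC[C@H](CSC[C@@H](N)C(=O)NCCN)OC(=O)CCCCCCCCCCC`, 5240 nM

Compound 2 gives the lowest of the two numbers in an assay on HEK293 cells for agonist activity at Toll-like receptor 2 (Homo sapiens); on this read-out lower numbers stand for an effect already at smaller amounts and higher numbers for an effect only at larger amounts of compound. Within the data shown here, its nearest neighbour is compound 1, and the only measured step, a 3.0-fold lower number from compound 1 to compound 2 (0.47 log units; beyond the scatter), is modest though beyond the scatter.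

Compound 3 `CCCCCCCCCCCC(=O)OC[C@H](CSC[C@@H](N)C(=O)NCCCN)OC(=O)CCCCCCCCCCC` is the next member. The change is aminomethyl in place of amino on a saturated chain carbon, two bonds along the chain from an amide-type nitrogen, which lengthens the amine-bearing chain by one saturated carbon while keeping the same donor and acceptor count. The step from compound 1 to compound 2 concerns the same amide substituent but replaces one group by another; it does not report on chain length alone. Among the measured compounds shown here, no measured step maps directly onto this change. Compound 3 is therefore expected to show a step of a 1.0-fold lower number from compound 2 to compound 3 (0.02 log units; within the scatter), not beyond the scatter. The estimate for compound 3 in this assay is 5000 nM, with a range from 2000 nM to 12000 nM.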

Compound 3, half-maximal effective concentration: 1960 nM
The estimate for compound 3 lay 2.6-fold (0.41 log units) above the measured number; the measured number lies below the stated range.
By their numbers in this assay, from the lowest: compound 3; then compound 2; then compound 1.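

In this assay the length of the amine-bearing chain matters on its own: with the terminal amine kept, aminomethyl in place of amino gives a 2.7-fold lower number from compound 2 to compound 3 (0.43 log units; beyond the scatter) and so separates 3-aminopropyl from 2-aminoethyl, something the earlier exchange of one whole group for another could not show. Set against the 1-(hydroxymethyl)-1-methylethyl group, 3-aminopropyl gives a 7.9-fold lower number from compound 1 to compound 3 (0.90 log units; beyond the scatter) and thus stands beyond the scatter from both other compounds. No supporting data are available to explain these differences.

On these data alone, whether the number keeps falling with a further carbon, as in 4-aminobutyl or a longer chain, remains open. Also open, as far as these compounds go, is whether the terminal amine is needed at all, a question that a hydroxyl or a carboxylic acid at the end of the same three-carbon chain would address.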